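Piperazine and diazepane pyrazoles: a chloro step at the limit

The source may hold more compounds than are shown below. What is called first, only, known or untested is meant among the compounds shown, and "the series" means these compounds.

Measured compounds:
Compound 1, `Clc1ccc(-c2n[nH]cc2N2CCCNCC2)cc1`, > 10000 nM
Compound 2, `c1ccc(-c2n[nH]cc2N2CCCNCC2)cc1`, > 10000 nM
Compound 3, `c1ccc(-c2n[nH]cc2N2CCNCC2)cc1`, > 10000 nM

In an assay on isolated protein for binding affinity to 5-hydroxytryptamine receptor 4 (Homo sapiens) (a higher number here means a weaker inhibitor, a lower number a stronger inhibitor), compound 2 is reported only as a limit of the assay, not as a number. Compound 1 likewise sits at a limit. Compound 3 too is given only as a limit; (the limit of > 10000 nM in this assay, at which 3 of the 3 values shown sit). Between compound 2 and compound 1 the change is chloro in place of hydrogen on an aromatic carbon, and the step is a step that the two limits leave unreadable from compound 2 to compound 1. The difference between the cores of compound 2 and compound 3 is not broken down here. Compound 4, `Clc1cccc(-c2n[nH]cc2N2CCNCC2)c1`, has not yet been measured. From compound 3 it differs by chloro in place of hydrogen on an aromatic carbon. This is the same kind of change as that from compound 2 to compound 1, but not the same: in the one case the chloro sits para to a large group, in the other meta to a large group. Because compound 3 already sits at > 10000 nM, a limit, and because the measured step that the two limits leave unreadable from compound 2 to compound 1 is unreadable, the expected step that the limit leaves unreadable from compound 3 to compound 4 cannot be read from the data either. For compound 4 the estimate in this assay is 15000 nM, most likely again a limit rather than a number.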

Compound 4, inhibition constant: > 10000 nM
Compound 4 gave a limit, no number; the forecaster's own chance of this, stated with the estimate: 85%; the middle value lies beyond the limit too.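

No new step can be read between compound 3 and compound 4 in this assay, as both are reported only as limits, not as numbers: the limit of > 10000 nM in this assay, at which 4 of the 4 values shown sit.

The compounds shown leave open how strongly any of them binds, and whether the chloro or the difference between the cores changes binding at all.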